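Isopropyl amide in place of aryl amide: mouse microsomal clearance

The source may report more compounds than this note shows. Statements on the series, on what has been measured and on what is new or still open speak of the compounds shown alone.

Measured compounds:
compound 1, `Cc1ccc(NC(=O)[C@H]2CN(C)C[C@@H]2c2ccc(/C=C/C(=O)Nc3ccccc3N)cc2)cc1`, 62 mL/min/kg
compound 2, `CN1C[C@H](C(=O)Nc2ccc(F)c(Cl)c2)[C@@H](c2ccc(/C=C/C(=O)Nc3ccccc3N)cc2)C1`, 34 mL/min/kg
compound 3, `CN1C[C@H](C(=O)Nc2ccc(F)c(Br)c2)[C@@H](c2ccc(/C=C/C(=O)Nc3ccccc3N)cc2)C1`, 43 mL/min/kg

All three were tested in an in vitro ADME assay on microsomes from liver (Mus musculus) for pharmacokinetics, read by LC-MS, with a stated time of 10 min, tested at 1 uM; a higher number here means faster removal of the compound, a lower number slower removal. Compound 3 holds the second highest of the three numbers; its nearest neighbour is compound 2, a 1.3-fold higher number from compound 2 to compound 3 (0.10 log units; within the scatter), and its furthest is compound 1, a 1.4-fold lower number from compound 1 to compound 3 (0.16 log units; within the scatter). Compound 4, `CC(C)NC(=O)[C@H]1CN(C)C[C@@H]1c1ccc(/C=C/C(=O)Nc2ccccc2N)cc1`, differs from compound 3 in one place: isopropyl in place of 3-bromo-4-fluorophenyl on an amide-type nitrogen. Among the compounds with values here, the measured steps of a 1.8-fold lower number from compound 1 to compound 2 (0.26 log units; within the scatter) and a 1.4-fold lower number from compound 1 to compound 3 (0.16 log units; within the scatter) exchange one aryl group for another and all remain within the scatter, but none exchanges an aryl group for an alkyl one, so no measured step bears directly on this change. No step beyond the scatter is expected. Compound 4 is estimated at 40 mL/min/kg, within 18 mL/min/kg to 85 mL/min/kg. The expected step is a 1.1-fold lower number from compound 3 to compound 4 (0.03 log units; within the scatter).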

Compound 4, clearance: 12 mL/min/kg
For compound 4 the middle estimate is 3.3-fold (0.52 log units) above the measured one, outside the stated range (below it).
By their numbers in this assay, from the lowest: compound 4; then compounds 2, 3 and 1 (each within the scatter of the next).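

In this assay, within the data shown here, isopropyl in place of an aryl group on the amide-type nitrogen gives a 3.6-fold lower number from compound 3 to compound 4 (0.55 log units; beyond the scatter) and a 2.8-fold lower number from compound 2 to compound 4 (0.45 log units; beyond the scatter) and a 5.2-fold lower number from compound 1 to compound 4 (0.71 log units; beyond the scatter) and these are the only steps in the set that lie beyond the scatter. This position therefore responds to an exchange of aryl for alkyl, while the exchanges among the three aryl groups do not separate the compounds. No measurement shown accounts for this gap.

The compounds shown do not separate the loss of the aromatic ring from the smaller count of heavy atoms. A cyclohexyl group on the same nitrogen, or a longer chain such as n-butyl, would bear on that.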